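Swapping a piperazine arm for a styryl arm on the core

The compounds below may be only part of what the source reports. "The series", "measured", "known", "first", "only" and "open" are said of these compounds alone.

Of the compounds shown here, three sharing one core have been measured in an ADME assay on microsomes from liver (Homo sapiens) for metabolic stability, read by LC-MS, using NADPH, tested at 5 uM; on this read-out lower numbers stand for a shorter-lived compound and higher numbers for a longer-lived compound. Compound 1 `CN1CCN(Cc2nnc(-c3cc(S(N)(=O)=O)c(SCc4ccccc4)cc3Cl)o2)CC1` gives 0.308 h in this assay. Compound 2 `NS(=O)(=O)c1cc(-c2nnc(CN3CCN(Cc4ccccc4)CC3)o2)c(Cl)cc1SCc1ccccc1` gives 0.08 h, and compound 3 `NS(=O)(=O)c1cc(-c2nnc(CN3CCN(c4ccc(F)cc4)CC3)o2)c(Cl)cc1SCc1ccccc1` gives 0.527 h. Among these, compound 1 stands second highest: its gap to compound 3 is within the scatter, while compound 2 lies clearly below it.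

Compound 4 `NS(=O)(=O)c1cc(-c2nnc(/C=C/c3ccccc3)o2)c(Cl)cc1SCc1ccccc1` has not yet been measured. Relative to compound 1, the change is 2-phenylethenyl in place of (4-methylpiperazin-1-yl)methyl on an aromatic carbon. Going by the values given here, none of the measured steps removes the piperazine ring itself; all three keep it and vary only what hangs from it. The closest comparison is the step of a 3.9-fold lower number from compound 1 to compound 2 (0.59 log units; beyond the scatter), where a phenyl was added onto the arm and the half-life fell. The step of a 1.7-fold higher number from compound 1 to compound 3 (0.23 log units; within the scatter) stayed within the scatter, and the step of a 6.6-fold higher number from compound 2 to compound 3 (0.82 log units; beyond the scatter) rose when a 4-fluorophenyl took the place of benzyl. These steps pull in different directions and none matches the present change, so the expectation is uncertain, leaning toward a shorter half-life for compound 4, expressed as a 1.7-fold lower number from compound 1 to compound 4 (0.23 log units; within the scatter). In this assay compound 4 is therefore estimated at 0.18 h, with a range from 0.06 h to 0.55 h.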

Compound 4, half-life: 0.228 h
Compound 4: the middle estimate sits 1.3-fold (0.10 log units) below what was measured, within the range that was stated.
By their numbers in this assay, from the lowest: compound 2; then compounds 4, 1 and 3 (each within the scatter of the next, the first and the last beyond it).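

Going by these compounds alone, every earlier compound kept the piperazine ring, so the step of a 1.4-fold lower number from compound 1 to compound 4 (0.13 log units; within the scatter) is the first look at what happens in this assay when that whole ring leaves the shared core. At this aromatic carbon of the five-membered aromatic ring, an arm of carbon only, with a six-membered aromatic ring and a double bond, gives a half-life that cannot be told apart from that of the (4-methylpiperazin-1-yl)methyl arm, so holding the half-life at this level does not require an amine ring in this pair. Nothing available here explains why the two arms land so close together.

This one change alters the ring, the double bond and the nitrogen atoms together, so the compounds shown leave open which of these parts matters for the half-life, or whether their contributions simply offset each other. A 2-phenylethyl arm, which lacks the double bond, and a morpholin-4-ylmethyl arm, which keeps the methyl link but has an oxygen in place of one ring nitrogen, would each separate part of that question.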